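Shortening the ester chain in a kinase inhibitor series

This account rests on a few compounds, and the source may have more. Where it says the series, first, only, none or still open, it means among the compounds named here.

Of the compounds shown here, three have been measured in an assay on isolated protein for inhibition of Rho-associated protein kinase 2 (Homo sapiens), read by radiometric assay; a higher number here means a weaker inhibitor, a lower number a stronger inhibitor. Compound 1, with structure `CCCCCCOC(=O)c1cccc(-c2cc(C(=O)Nc3ccncc3)ccc2CN)c1`, gives 22 nM and stands second highest of the three numbers. Compound 2, with structure `CC(C)OCCOC(=O)c1cccc(-c2cc(C(=O)Nc3ccncc3F)ccc2CN)c1`, gives 37 nM, a number that lies within the usual scatter of compound 1. Compound 3, with structure `CC(N)c1ccc(C(=O)Nc2ccncc2)cc1-c1ccc(F)cc1`, gives 1.2 nM, far below compound 1 and beyond the scatter.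

Compound 4, with structure `CCCOC(=O)c1cccc(-c2cc(C(=O)Nc3ccncc3)ccc2CN)c1`, has not yet been measured. It differs from compound 1 in one place: hydrogen in place of propyl on a saturated chain carbon, three bonds along the chain from an oxygen next to a carbonyl group. The ester chain is cut from hexyl down to propyl; the shared core and the amide are untouched.

For the measured compounds named here, no measured pair in this set shows a change of this kind, so no step can be read off directly. Since compound 2, which carries a different ester chain, stays within the scatter of compound 1, the step from compound 1 to compound 4 is expected to be small, a 1.4-fold higher number from compound 1 to compound 4 (0.13 log units; within the scatter), with no clear direction beyond the scatter. Compound 4 is therefore estimated at 30 nM in this assay, within a range of 12 nM to 80 nM.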

Compound 4, half-maximal inhibitory concentration: 1.4 nM
The estimate for compound 4 lay 21-fold (1.33 log units) above the measured number, and the stated range ends above it.
By their numbers in this assay, from the lowest: compounds 3 and 4 (each within the scatter of the next); then compounds 1 and 2 (each within the scatter of the next).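

In this assay, cutting the ester chain from hexyl to propyl gives a 16-fold lower number from compound 1 to compound 4 (1.20 log units; beyond the scatter) and shows that the length of this chain matters a great deal, even though the shared core and the amide stay the same. For the compounds shown here, the earlier compounds held no pair differing only in this chain, so this is the first direct sign that the position is sensitive to such a change, and that removing chain carbons here can strengthen inhibition. Nothing available explains why the shorter chain gives the lower number.

Two chain lengths cannot show whether the number falls steadily or changes abruptly, so a butyl or pentyl chain could lie anywhere between them or outside them. From the compounds shown here alone, whether an ethyl or methyl ester would go lower still remains open, as does the effect of replacing the ester with a carboxylic acid.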